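Chain Extension on the Piperidine Arm of Compound 2

The source may hold more compounds than are shown below. What is called first, only, known or untested is meant among the compounds shown, and "the series" means these compounds.

Three analogues sharing one core have been measured in a functional assay on M21 cells (Homo sapiens) for antiproliferative activity, read by sulforhodamine B assay, with a stated time of 48 h; a lower number here means a stronger inhibitor of growth, a higher number a weaker inhibitor of growth. Compound 1 `CCCCc1ccc(-c2cc(N3CCC(CNS(N)(=O)=O)CC3)ncn2)cc1` gives 47200 nM, compound 2 `CC(C)(C)c1ccc(-c2cc(N3CCC(CNS(N)(=O)=O)CC3)ncn2)cc1` gives 19300 nM, and compound 3 `NS(=O)(=O)NCC1CCN(c2cc(-c3ccc(Cl)cc3)ncn2)CC1` gives 50300 nM. Among these three, compound 2 holds the lowest number: the step of a 2.4-fold lower number from compound 1 to compound 2 (0.39 log units; beyond the scatter) and the step of a 2.6-fold higher number from compound 2 to compound 3 (0.42 log units; beyond the scatter) both lie beyond the scatter, while a 1.1-fold higher number from compound 1 to compound 3 (0.03 log units; within the scatter) does not.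

Compound 4 `CC(C)(C)c1ccc(-c2cc(N3CCC(CCNS(N)(=O)=O)CC3)ncn2)cc1` keeps the tert-butyl group of compound 2 and alters only the saturated arm: (sulfamoylamino)methyl in place of sulfamoylamino on a saturated chain carbon bound to a saturated ring carbon. None of the three measured steps touches this part of the molecule; each of them swaps the substituent on the aromatic carbon and leaves the arm unchanged. The data therefore give no direct guide to lengthening the chain by one carbon, and the expectation rests on the closeness of the two structures alone. In this assay a step of no more than the usual scatter is expected from compound 2 to compound 4, with no direction favoured, so that a 1.1-fold higher number from compound 2 to compound 4 (0.06 log units; within the scatter) is the estimated change. Compound 4 is accordingly expected to give about 22000 nM, with a plausible range from 8000 nM to 60000 nM.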

Compound 4, concentration for 50% growth inhibition: 18400 nM
Compound 4: the middle estimate sits 1.2-fold (0.08 log units) above what was measured; low and high end bracket the measured number.
By their numbers in this assay, from the lowest: compounds 4 and 2 (each within the scatter of the next); then compounds 1 and 3 (each within the scatter of the next).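

In this assay, the arm of compound 2 was extended by one carbon, turning (sulfamoylamino)methyl into 2-(sulfamoylamino)ethyl, and this gives a 1.0-fold lower number from compound 2 to compound 4 (0.02 log units; within the scatter). Going by these compounds alone, this is the first reading at this position, as the earlier steps all exchanged the substituent on the aromatic carbon, and it shows that, with tert-butyl in place, the two arm lengths cannot be told apart in this assay. No measurement is available that would explain this result.

As far as these compounds go, the result covers a single extension with a single aromatic substituent, so it remains open whether the same added carbon would be equally silent with the butyl group of compound 1 or the chloro group of compound 3. Also open, from the compounds shown here alone, is how the number would respond to a longer chain, such as 3-(sulfamoylamino)propyl, or to an amine or a carboxylic acid in place of the sulfamoylamino group at the end of the arm.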